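The compounds below may be only part of what the source reports. "The series", "measured", "known", "first", "only" and "open" are said of these compounds alone.

Of the compounds shown here, three have been measured in a functional assay on the whole organism for antagonist activity, with Mus musculus as the target (on this read-out lower numbers stand for an effect already at smaller amounts and higher numbers for an effect only at larger amounts of compound), and none of them has yet given an actual number. Compound 1 `COC(=O)N(C)C(C)C#CCn1ccnc1` gives > 100 mg/kg, which is a limit of the assay. Compound 2 `CN(C)C(=O)N(C)CC#CCN1CCCC1` gives > 10 mg/kg, which is also a limit. Compound 3 `Cn1ccn(CC#CCN2CCCC2)c1=O` gives > 10 mg/kg, a limit as well. Compound 3 thus sits at the limit of > 10 mg/kg in this assay, at which 2 of the 3 values shown sit.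

Compound 4 `Cn1ccn(CC#CCn2ccnc2)c1=O` differs from compound 3 in one place, with 1H-imidazol-1-yl in place of pyrrolidin-1-yl on a saturated chain carbon bound to a triple-bonded carbon. Going by the values given here, no two measured compounds differ in only one place, so no measured step is available as a guide. Among the compounds with values here, the one measured compound that carries 1H-imidazol-1-yl is compound 1, and the expectation leans on its limit of > 100 mg/kg. In this assay, the change is therefore expected to bring no gain, and at most a modest shift towards larger amounts of compound. The estimated step is a step that the limit leaves unreadable from compound 3 to compound 4. For compound 4 the expected value is 30 mg/kg, within an estimated range of 10 mg/kg to 100 mg/kg. Another reading that is only a limit would be the likeliest outcome.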

Compound 4, dose for half-maximal effect: > 100 mg/kg
Compound 4: only a limit was reported (the forecaster's own chance of this, stated with the estimate: 85%); middle value at least 3.3-fold (0.52 log units) away from the limit.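

In this assay compound 3 and compound 4 each gave only a limit, so the size of the step from 1H-imidazol-1-yl in place of pyrrolidin-1-yl cannot be read. The compounds shown leave open what dose any of them needs for a half-maximal effect, and whether either group does better than the other.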